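A few compounds are considered here, and "the series" means these few. Any claim that something is new, unique, unknown or untested is made for them only; others in the source may bear on it.

Measured compounds:
compound 1 `N#CC1=C(N)Oc2c(ccc(N)c2N)C1c1cccc(C#N)c1`: 390000000 nM
compound 2 `N#CC1=C(N)Oc2c(ccc(N)c2N)C1c1cccc([N+](=O)[O-])c1`: 390000000 nM

In a functional assay on T47D cells (Homo sapiens) for activation (on this read-out lower numbers stand for an effect already at smaller amounts and higher numbers for an effect only at larger amounts of compound), compound 2 stands level with compound 1 at the digits shown; the step of no change at the digits printed from compound 1 to compound 2 (within the scatter) lies within the scatter. Compound 3 `N#CC1=C(N)Oc2c(ccc(N)c2N)C1c1cccc(Br)c1` is the next entry, with bromo in place of nitro on an aromatic carbon. Among the compounds with values here, the only measured step bearing on this change is no change at the digits printed from compound 1 to compound 2 (within the scatter), where a different substituent at the same place left the read-out unmoved. Accordingly no shift beyond the scatter is expected for compound 3 in this assay, the expected step being no change at the digits printed from compound 2 to compound 3 (within the scatter). Compound 3 is thus estimated at 390000000 nM, with an expected range from 195000000 nM to 780000000 nM.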

Compound 3, half-maximal effective concentration: 150000000 nM
Beside the measured number, compound 3's estimate is 2.6-fold (0.41 log units) above it; measured number below the stated range.
By their numbers in this assay, from the lowest: compound 3; then compounds 1 and 2 (each within the scatter of the next).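

In this assay this place on the aromatic ring proves responsive to substitution: bromo gives a 2.6-fold lower number from compound 2 to compound 3 (0.41 log units; beyond the scatter) and a 2.6-fold lower number from compound 1 to compound 3 (0.41 log units; beyond the scatter), whereas nitrile and nitro read level with each other. The steps are modest, and bromo, with no hydrogen-bond acceptors, is the only group shown to move the number. Nothing available explains this shift.

The compounds shown leave open whether chloro or methyl at this place would read like bromo. They also leave open whether an amine or a carboxylic acid there would move the number in either direction.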